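Hydroxy for bromo on a naphthyloxyacetohydrazone series

The source may report more compounds than this note shows. Statements on the series, on what has been measured and on what is new or still open speak of the compounds shown alone.

Compound 1, `O=C(COc1cccc2ccccc12)N/N=C/c1ccc(O)cc1`, in an ADME assay on HEL cells (Homo sapiens) for cytotoxicity (on this read-out lower numbers stand for higher toxicity in this test and higher numbers for lower toxicity in this test), gives 20 ug/mL.
Compound 2, `O=C(COc1cccc2ccccc12)N/N=C/c1ccc(Br)cc1`, in this assay gives > 100 ug/mL, which is a limit of the assay and not a number.
Compound 3, `C/C(=N\NC(=O)COc1cccc2ccccc12)c1ccc(Br)cc1`, in this assay gives 20 ug/mL.

Of the compounds shown here, three have been measured so far. Compound 2 and compound 1 differ in one place only, (hydroxy in place of bromo on an aromatic carbon), and this change brought an at least 5.0-fold lower number from compound 2 to compound 1 (0.69 log units; beyond the scatter); the starting point of that step is the limit recorded for compound 2, (the limit of > 100 ug/mL in this assay, at which 1 of the 3 values shown sits). Compound 3 carries a different core; the difference between the two cores of compound 2 and compound 3 is not broken down here. In this assay compound 3 and compound 1 stand level at the digits printed, within the scatter of the method.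

The compound not yet measured is compound 4, `C/C(=N\NC(=O)COc1cccc2ccccc12)c1ccc(O)cc1`. It differs from compound 3 by hydroxy in place of bromo on an aromatic carbon, the same change that turned compound 2 into compound 1, at the same place. On that basis the step of a 2.0-fold lower number from compound 3 to compound 4 (0.30 log units; within the scatter) is expected, because the same change produced an at least 5.0-fold lower number from compound 2 to compound 1 (0.69 log units; beyond the scatter), though compound 3 already sits at the lower value and the earlier step began from a limit. Compound 4 is estimated at 10 ug/mL, with a range from 3 ug/mL to 50 ug/mL.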

Compound 4, minimum cytotoxic concentration: 20 ug/mL
Estimate against measurement, compound 4: 2.0-fold (0.30 log units) below; the range from low to high includes it.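

In this assay, hydroxy in place of bromo on an aromatic carbon, here 4-bromophenyl to 4-hydroxyphenyl, brought no change at the digits printed from compound 3 to compound 4 (within the scatter), so the change did not carry over from one core to the other at the size first seen: the same change on two cores in this assay, an at least 5.0-fold lower number (0.69 log units; beyond the scatter) from compound 2 to compound 1 and no change at the digits printed (within the scatter) from compound 3 to compound 4, at least 5.0-fold (0.69 log units) apart, beyond the scatter of two such steps. Going by these compounds, compound 2 gives > 100 ug/mL, which is a limit of the assay and not a number, so the true size of the first step remains unknown and only a minimum can be given for the gap between the two steps: the limit of > 100 ug/mL in this assay, at which 1 of the 4 values shown sits. The four compounds do not show why the outcome differs between the cores, or how the change would behave on a third core.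

The compounds shown leave open how an amine, a methoxy group or a carboxylic acid in the same place on the ring would read in this assay. They also leave open whether either core would give the same picture in cells other than those of this test.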